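A few compounds are considered here, and "the series" means these few. Any claim that something is new, unique, unknown or untested is made for them only; others in the source may bear on it.

Of the compounds shown here, three sharing one core have been tested in a functional assay on MCF7 cells (Homo sapiens) for antiproliferative activity, read by MTT assay, with a stated time of 48 h (on this read-out higher numbers stand for weaker inhibition and lower numbers for stronger inhibition), and none gives a number. Compound 1 `C=C1[C@H](OCC(C)C)C2=C(C[C@@](C)(OC(C)=O)[C@@H]2OC(C)=O)[C@@H](OC(=O)c2ccccc2)[C@@H](C)/C=C/C(C)(C)[C@H](OC(C)=O)[C@H](OC(C)=O)[C@H]1OCC(C)C` reads > 100000 nM, which is a limit of the assay. Compound 2 `C=C1[C@H](O)[C@@H](O)[C@@H](O)C(C)(C)/C=C/[C@H](C)[C@H](OC(=O)c2ccccc2)[C@@]2(O)C[C@@](C)(O)[C@H](OC(C)=O)[C@@H]2[C@H]1OCC(C)C` reads > 100000 nM, again a limit. Compound 3 `C=C1[C@H](OC(C)=O)[C@@H](OC(C)=O)[C@@H](OC(C)=O)C(C)(C)/C=C/[C@H](C)[C@H](OC(=O)c2ccccc2)[C@@]2(O)C[C@@](C)(O)[C@H](OC(C)=O)[C@@H]2[C@H]1OCC(C)C` reads > 100000 nM, also a limit. Compound 2 therefore has no measured potency of its own and stands with compound 1 and compound 3 at the limit of > 100000 nM in this assay, at which 3 of the 3 values shown sit.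

Compound 4 `C=C1[C@H](O)[C@@H](OC(=O)c2cccc(C)c2)[C@@H](O)C(C)(C)/C=C/[C@H](C)[C@H](OC(=O)c2ccccc2)[C@@]2(O)C[C@@](C)(O)[C@H](OC(C)=O)[C@@H]2[C@H]1OCC(C)C` has yet to be measured in this assay. It differs from compound 2 by one change: (3-methylphenyl)carbonyl in place of hydrogen on an oxygen on a saturated carbon. A (3-methylphenyl)carbonyl takes the place of hydrogen on an oxygen on a saturated carbon, so a hydroxy becomes ((3-methylphenyl)carbonyl)oxy.

No measured step among these compounds shows what such a change does, so the expectation rests only on (the limit of > 100000 nM in this assay, at which 3 of the 3 values shown sit). A modest move toward stronger inhibition is expected, though the result may well remain a limit. The estimated shift, an at least 1.4-fold lower number from compound 2 to compound 4 (0.15 log units; that floor lies within the scatter), is therefore small and uncertain. For compound 4 the estimated value is 70000 nM, with an expected range from 20000 nM to 100000 nM.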

Compound 4, half-maximal inhibitory concentration: 63800 nM
The estimate for compound 4 lay 1.1-fold (0.04 log units) above the measured number; measured number inside the range.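

In this assay, among the compounds shown here, turning the hydroxy into ((3-methylphenyl)carbonyl)oxy on this oxygen gives the first step in the set that can be read at all: an at least 1.5-fold lower number from compound 2 to compound 4 (0.19 log units; that floor lies within the scatter). Compound 4 gives 63800 nM, so this position accepts the large (3-methylphenyl)carbonyl group, with its six-membered aromatic ring, and still yields a number. Compound 1, compound 2 and compound 3 offered only limits. That number stands alone among the values shown, and the step is a floor rather than a full size, so it shows that a readable value can be reached here but not how far the change moves the potency: the limit of > 100000 nM in this assay, at which 3 of the 4 values shown sit.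

The compounds shown leave open whether the methyl on the ring matters, since a plain benzoyl on the same oxygen does not appear among them, and whether a longer acyl chain or a group carrying an amine would give a lower number still. They also leave open whether the same (3-methylphenyl)carbonyl on either of the other two hydroxy groups that compound 2 carries on this part of the ring would give a similar step.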